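This account rests on a few compounds, and the source may have more. Where it says the series, first, only, none or still open, it means among the compounds named here.

Working notes on the series. Compound 1 `O/N=C(/Nc1ccc(F)c(Cl)c1)c1ccc2occc2c1` in an assay on tissue (HeLa cells) for inhibition of Indoleamine 2,3-dioxygenase 1 (Homo sapiens), read by spectrophotometry (on this read-out lower numbers stand for stronger inhibition and higher numbers for weaker inhibition), gives 1800 nM. Compound 2 `O/N=C(/NCc1ccccc1)c1ccc2occc2c1` in this assay gives 28200 nM, the highest of the two numbers recorded so far; the gap between compound 2 and compound 1 lies well beyond the usual scatter, so compound 2 stands clearly at the weak end of what has been measured. Compound 3 `O/N=C(/NCc1cccc(Cl)c1)c1ccc2occc2c1` is not yet measured. It differs from compound 2 in a single place: chloro in place of hydrogen on an aromatic carbon. For the measured compounds named here, no measured pair in the set shows this exact change, so the size of the step in this assay has to be judged from the rest of the series. Compound 1, which also carries a chloro on an aromatic carbon, gives 1800 nM, the lower of the two numbers, and on that basis a modest drop in the number for compound 3 is expected, though a step that stays within the scatter cannot be excluded. Compound 3 is estimated at 12000 nM, with a range of 4000 nM to 35000 nM. The step expected from compound 2 to compound 3 is a 2.4-fold lower number from compound 2 to compound 3 (0.37 log units; beyond the scatter).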

Compound 3, half-maximal inhibitory concentration: 5800 nM
Beside the measured number, compound 3's estimate is 2.1-fold (0.32 log units) above it; measured number inside the range.
By their numbers in this assay, from the lowest: compound 1; then compound 3; then compound 2.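

In this assay, the change from phenyl to 3-chlorophenyl gives the series its first reading of a single change, a 4.9-fold lower number from compound 2 to compound 3 (0.69 log units; beyond the scatter). This step is modest in size but beyond the scatter, so a single chlorine on an aromatic carbon, meta to a large group, is enough to move the number in the stronger direction on this otherwise unchanged compound. Compound 1 and compound 2 differ in more than one place and could not isolate this effect, whereas the present pair ties the shift to this one position and this one substituent.

The compounds shown leave open whether the shift is specific to chloro, since fluoro, methyl, methoxy, an amine or a carboxylic acid at this place would each need its own reading. They also do not show whether chloro on another carbon of the same ring gives a step of similar size, or whether the same change would carry over to other compounds in the series. Nothing measured here accounts for the size or direction of the step.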